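Swapping Hydroxy for Acetyl on the Aryl Arm

The source may report more compounds than this note shows. Statements on the series, on what has been measured and on what is new or still open speak of the compounds shown alone.

Three compounds share one core and differ only in the aryl group attached to it. Compound 1 `COc1cc(-n2cnc3ccc(-c4cccc([N+](=O)[O-])c4)cc32)cc(OC)c1OC` gives 5410 nM in a functional assay on A549 cells (Homo sapiens) for antiproliferative activity, read by MTT assay, with a stated time of 72 h; a higher number here means a weaker inhibitor, a lower number a stronger inhibitor; compound 2 `COc1cc(-n2cnc3ccc(-c4cccc(C)c4)cc32)cc(OC)c1OC` gives 3820 nM; compound 3 `COc1cc(-n2cnc3ccc(-c4ccc(O)cc4)cc32)cc(OC)c1OC` gives 5090 nM. Compound 3 stands second highest of the three numbers, yet a 1.1-fold lower number from compound 1 to compound 3 (0.03 log units; within the scatter) and a 1.3-fold higher number from compound 2 to compound 3 (0.12 log units; within the scatter) both lie within the scatter, so no order among the three can be read. Compound 4 `COc1cc(-n2cnc3ccc(-c4ccc(C(C)=O)cc4)cc32)cc(OC)c1OC` is the next step: acetyl in place of hydroxy on an aromatic carbon. Among the compounds with values here, the steps that bear on it are the two just named, both small and both altering the same aryl ring. With nothing beyond the scatter so far, a step within the scatter is expected, namely a 1.0-fold lower number from compound 3 to compound 4 (0.01 log units; within the scatter). Compound 4 is therefore estimated at about 5000 nM, between 2500 nM and 10000 nM.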

Compound 4, half-maximal inhibitory concentration: 2510 nM
For compound 4 the middle estimate is 2.0-fold (0.30 log units) above the measured one, within the range that was stated.
By their numbers in this assay, from the lowest: compounds 4, 2, 3 and 1 (each within the scatter of the next, the first and the last beyond it).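

Acetyl in place of hydroxy, para to a large group, gives the first step on this aryl arm that passes the scatter (a 2.0-fold lower number from compound 3 to compound 4 (0.31 log units; beyond the scatter)), and 4-acetylphenyl in place of 3-nitrophenyl also passes it (a 2.2-fold lower number from compound 1 to compound 4 (0.33 log units; beyond the scatter)), both modest. Against 3-methylphenyl the change stays within the scatter (a 1.5-fold lower number from compound 2 to compound 4 (0.18 log units; within the scatter)), so compound 2 and compound 4 cannot be ordered. No measurement at hand explains why acetyl and hydroxy differ here. On these data alone, whether an amine, a carboxylic acid or a longer chain at this place would move the number further in this assay stays open.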